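Configuration-only changes: from compound 2 to compound 3

This account rests on a few compounds, and the source may have more. Where it says the series, first, only, none or still open, it means among the compounds named here.

Measured in a functional assay on RAW264.7 cells (Mus musculus) for inhibition, read by Griess assay, with a stated time of 24 h; a lower number here means a stronger inhibitor, a higher number a weaker inhibitor:
- compound 1 `CO[C@H]1CC(=O)O[C@@H]1[C@@]1(C)CC(=O)c2c(cc(C)c(-c3c(C)cc4c(c3O)C(=O)C[C@@](C)([C@H]3OC(=O)C[C@@H]3OC)O4)c2O)O1`: > 10000 nM
- compound 2 `CO[C@H]1CC(=O)O[C@@H]1[C@@]1(C)CC(=O)c2c(cc(C)c(-c3c(C)cc4c(c3O)C(=O)C[C@](C)([C@H]3OC(=O)C[C@@H]3OC)O4)c2O)O1`: 5200 nM

Not yet measured: compound 3 `CO[C@H]1CC(=O)O[C@@H]1[C@]1(C)CC(=O)c2c(cc(C)c(-c3c(C)cc4c(c3O)C(=O)C[C@@](C)([C@H]3OC(=O)C[C@@H]3OC)O4)c2O)O1`.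

The entry for compound 1, > 10000 nM, is a limit of the assay and not a number. Within the data shown here, compound 2 stands at 5200 nM, the only true number in this assay so far. The next change is the two compounds have the same atoms and bonds and differ only in configuration as drawn: 2 of 6 stereo elements differ; a stereocentre at a saturated ring carbon is drawn R in compound 2 and S in compound 3; a stereocentre at a saturated ring carbon is drawn R in compound 2 and S in compound 3. Among the measured compounds shown here, one measured step bears on it: an at least 1.9-fold lower number from compound 1 to compound 2 (0.28 log units; that floor lies within the scatter). That step rests on (the fact that compounds 1 and 2 differ only in the configuration as drawn), and its size is bounded only by the limit of > 10000 nM in this assay, at which 1 of the 2 values shown sits. No firm size therefore carries over to the two stereocentres that change here, and no shift beyond the scatter is expected in this assay, with a slightly higher number the likelier side. The expected change is a 1.3-fold higher number from compound 2 to compound 3 (0.13 log units; within the scatter). For compound 3 the estimated value is 7000 nM, with an expected range of 2500 nM to 20000 nM.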

Compound 3, half-maximal inhibitory concentration: > 10000 nM
Compound 3: no number, only a limit (the forecaster's own chance of this, stated with the estimate: 40%); middle value at least 1.4-fold (0.15 log units) from the limit.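

Compound 3 gives > 10000 nM in this assay, which is a limit of the assay and not a number. Among these compounds, the one readable new step is an at least 1.9-fold higher number from compound 2 to compound 3 (0.28 log units; that floor lies within the scatter), so only its floor is known, and the step between the two compounds held at the limit cannot be read. Compound 2 remains the only one of these three stereoisomers with a true number, and any shift here rests on configuration alone: the fact that compounds 2 and 3 differ only in the configuration as drawn.

Which of the two changed stereocentres matters in this assay, and how large either step really is, stays open. Also open, on these data alone, is whether an amine or a carboxylic acid on the shared core would give a true number in the configurations of compound 1 and compound 3.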